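This account rests on a few compounds, and the source may have more. Where it says the series, first, only, none or still open, it means among the compounds named here.

Compound 1 `CCCC(=O)N1CC2CC(C1)N2` has the highest of the three numbers measured in an assay on CHO cells for agonist activity at Neuronal acetylcholine receptor; alpha3/alpha6/beta2/beta3 (Homo sapiens), read by FLIPR and calcium flux (a higher number here means a larger maximal response, a lower number a smaller maximal response), where compound 1 gives 92%. Compound 2 `O=C(C1CCCC1)N1CC2CC(C1)N2` gives 62% in this assay, and compound 3 `O=C(CC1C=CCC1)N1CC2CC(C1)N2` gives 47% in this assay. For the measured compounds named here, the one step that can be followed through a single change is the step from compound 1 to compound 3 a number 45 percentage points lower from compound 1 to compound 3 (beyond the scatter), a large loss when a ring enters the acyl chain. Compound 4 `O=C([C@@H]1C[C@@H]1F)N1CC2CC(C1)N2` differs from compound 1 in another way: 2-fluorocyclopropyl in place of propyl on a carbonyl carbon. Going by the values given here, no measured step exchanges a chain for a small ring directly on the carbonyl carbon, so only the two ring-bearing neighbours can guide the expectation. Both compound 2 and compound 3 fall well short of compound 1 in this assay, which points toward a lower maximal response for compound 4 as well. Compound 4 is therefore expected to lose ground in this assay, by an estimated a number 30 percentage points lower from compound 1 to compound 4 (beyond the scatter). The estimate for compound 4 in this assay is 62%, with a range from 38% to 86%.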

Compound 4, largest response reached (Emax), in percent of the reference or control that the assay uses: 120%
Estimate against measurement, compound 4: 58 percentage points below; the whole stated range lies below it.
By their numbers in this assay, from the lowest: compound 3; then compound 2; then compound 1; then compound 4.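

Putting 2-fluorocyclopropyl in place of propyl on the carbonyl carbon gives a number 28 percentage points higher from compound 1 to compound 4 (beyond the scatter) in this assay, which shows that a ring at this position can accompany a rise and not only a loss. A ring on the carbonyl carbon does not by itself settle the outcome: compound 2 gives 62%, whereas compound 4 gives 120%. Nothing available accounts for this rise.

The compounds shown do not separate the contribution of the three-membered ring from that of the fluorine, a question that plain cyclopropyl on the same carbonyl carbon would address. Also open, on these data alone, is how the other stereoisomers of 2-fluorocyclopropyl would compare with compound 4 at this position.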